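The compounds below may be only part of what the source reports. "The series", "measured", "known", "first", "only" and "open" are said of these compounds alone.

Measured in a functional assay on MCF7 cells (Homo sapiens) for inhibition, read by sulforhodamine B assay, with a stated time of 48 h; a lower number here means a stronger inhibitor of growth, a higher number a weaker inhibitor of growth:
- compound 1 `c1cc(OC2CCCCC2)ccc1NC1=NCCO1`: 19100 nM
- compound 2 `O=C(CCl)NC(=O)Nc1ccc(C2CCCCC2)cc1`: 1500 nM
- compound 3 `O=C(CCl)NC(=O)Nc1cccc(OC2CCCCCC2)c1`: 7200 nM

Compound 2 holds the lowest of the three numbers in this assay, which makes it the strongest inhibitor of growth so far. Its gaps to compound 3 and to compound 1 both lie beyond the scatter.

The next compound to be tested is compound 4 `O=C(CCl)NC(=O)Nc1ccc(Oc2ccccc2)cc1`, which differs from compound 2 in one place: phenoxy in place of cyclohexyl on an aromatic carbon. Phenoxy replaces cyclohexyl on an aromatic carbon, para to a group of 8 heavy atoms, and the rest of the structure is unchanged.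

Among the measured compounds shown here, no step between measured compounds differing in one place is available, so the size of this change has no direct precedent. For the measured compounds named here, the three values show only that the numbers spread widely across differing structures. Compound 3 is the closer measured neighbour of compound 2, and compound 3 gives 7200 nM, which serves as a loose upper guide. A small move towards a higher number is expected, perhaps not beyond the scatter. The expected change is a 1.7-fold higher number from compound 2 to compound 4 (0.22 log units; within the scatter). For compound 4 the estimated value is 2500 nM, with an expected range of 900 nM to 7000 nM.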

Compound 4, concentration for 50% growth inhibition: 4200 nM
The estimate for compound 4 lay 1.7-fold (0.23 log units) below the measured number; measured number inside the range.
By their numbers in this assay, from the lowest: compound 2; then compounds 4 and 3 (each within the scatter of the next); then compound 1.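

In this assay, the place on an aromatic carbon para to a group of 8 heavy atoms now has its first one-place comparison: phenoxy in place of cyclohexyl gives a 2.8-fold higher number from compound 2 to compound 4 (0.45 log units; beyond the scatter), a modest step that shows the number at this place depends on which of these two groups it carries. The change does not abolish growth inhibition, since compound 4 still gives 4200 nM with an aromatic ring and an added oxygen in the entering group, but this single step cannot separate the contribution of the aromatic ring from that of the oxygen, which also brings a hydrogen-bond acceptor. Nothing available bears on the cause of this step.

Whether the oxygen or the ring type accounts for the step remains open, and a phenyl group or a cyclohexyloxy group at this place on the shared core of compounds 2 and 4 would divide the two. Also open, going by these compounds, is how far the number at this place moves with much smaller or differently built groups, such as a methoxy group, an amine or a longer alkyl chain.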